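The source may hold more compounds than are shown below. What is called first, only, known or untested is meant among the compounds shown, and "the series" means these compounds.

Measured in an ADME assay (liver) for metabolic stability, with Liver microsome (Rattus norvegicus) as the target, using microsomes and NADPH, with a stated time of 30 min; on this read-out lower numbers stand for slow clearance and higher numbers for fast clearance:
Compound 1 `CC#C[C@H]1CN(S(=O)(=O)c2ccc(N)nc2)CCN1c1ccccc1`: > 399 mL.min-1.g-1, a limit of the assay
Compound 2 `CC#C[C@H]1CN(S(=O)(=O)c2ccc(N)nc2)CCN1c1ccc(S(=O)(=NC)C(F)(F)F)cc1`: 257 mL.min-1.g-1

Of these two entries, only compound 2 has an actual number, 257 mL.min-1.g-1. The entry for compound 1, > 399 mL.min-1.g-1, is a limit and not a number.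

The next compound, compound 3 `CC#C[C@H]1CN(S(=O)(=O)c2ccc(N)nc2)CCN1c1ccc(C(O)(COC)C(F)(F)F)cc1`, keeps the core of compound 2 and changes one group, on an aromatic carbon of a six-membered aromatic ring of carbon only, para to a large group: a group of 9 heavy atoms (4 carbon, 2 oxygen, 3 fluorine; no ring) in place of a group of 8 heavy atoms (2 carbon, 1 nitrogen, 1 oxygen, 3 fluorine, 1 sulfur; no ring), on an aromatic carbon.

Within the data shown here, only one measured step bears on this change: an at least 1.5-fold lower number from compound 1 to compound 2 (0.19 log units; that floor lies within the scatter). In that step, the group that compound 3 gives up took the place of a hydrogen atom, and the floor of the step lies within the scatter. It sets no firm size for swapping that group for another, so the expectation starts from compound 2 at 257 mL.min-1.g-1.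

In this assay, no step beyond the scatter is expected, and the estimated step is a 1.4-fold lower number from compound 2 to compound 3 (0.15 log units; within the scatter). For compound 3 the expected value is 180 mL.min-1.g-1, with an estimated range from 70 mL.min-1.g-1 to 400 mL.min-1.g-1.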

Compound 3, intrinsic clearance in microsomes: 93 mL.min-1.g-1
Compound 3: middle estimate off by 1.9-fold (0.29 log units), on the high side; measured number inside the range.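

In this assay, this aromatic carbon responds to which group it carries and not only to whether it carries one: exchanging one fluorine-bearing group without a ring for another gives a 2.8-fold lower number from compound 2 to compound 3 (0.44 log units; beyond the scatter). The earlier pair offered only a floor within the scatter, whereas a group at this carbon now gives an at least 4.2-fold lower number from compound 1 to compound 3 (0.63 log units; beyond the scatter), which clearly separates a substituted compound from the unsubstituted compound 1. That second step is still only a floor, and its full size cannot be read: the limit of > 399 mL.min-1.g-1 in this assay, at which 1 of the 3 values shown sits.

The exchange replaces the sulfur and nitrogen of the leaving group with a carbon framework, a hydroxyl and a methoxymethyl chain, and it adds a hydrogen-bond donor, so compound 2 and compound 3 cannot show which of these features goes with the lower number. From the compounds shown here alone, it also remains open whether a simpler group at this carbon, such as a plain trifluoromethyl, a nitrile or an amine, would give slower clearance still, and whether the hydroxyl or the methoxymethyl chain alone would keep the lower number.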